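The source may hold more compounds than are shown below. What is called first, only, known or untested is meant among the compounds shown, and "the series" means these compounds.

In a functional assay on HL-60 cells (Homo sapiens) for inhibition, read by MTT assay, with a stated time of 72 h (a lower number here means a stronger inhibitor, a higher number a weaker inhibitor), compound 1 `Cc1ccc(-c2cn(-c3ccc(CN4CCN(C)CC4)cc3)nn2)cc1Nc1nccc(-c2cccnc2)n1` gives 6740 nM; compound 2 `Cc1ccc(-c2cn(-c3ccc(CN4CCN(C)CC4)c(C(F)(F)F)c3)nn2)cc1Nc1nccc(-c2cccnc2)n1` gives 20 nM; compound 3 `Cc1ccc(-c2nnc(-c3ccc(CN4CCN(CCN=C=S)CC4)c(C(F)(F)F)c3)o2)cc1Nc1nccc(-c2cccnc2)n1` gives 70 nM.

Compounds 2 and 1 differ in a single place: hydrogen in place of trifluoromethyl on an aromatic carbon. That one change gave a 340-fold higher number from compound 2 to compound 1 (2.53 log units; beyond the scatter), the biggest step among these compounds. Compound 3 carries a different core from compound 2, and the difference between the two cores is not broken down here; the two values show compound 3 standing somewhat weaker than compound 2.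

Compound 4 `Cc1ccc(-c2nnc(-c3ccc(CN4CCN(CCN=C=S)CC4)cc3)o2)cc1Nc1nccc(-c2cccnc2)n1` is not yet measured. It stands to compound 3 as compound 1 stands to compound 2: hydrogen in place of trifluoromethyl on an aromatic carbon. The surroundings are not identical, though. In compound 3 the position is ortho to a large group and meta to a large group, whereas in compound 2 it is ortho to a (4-methylpiperazin-1-yl)methyl group and meta to a large group, so this is the same kind of change rather than the same change.

Compound 4 is therefore expected to show a 140-fold higher number from compound 3 to compound 4 (2.15 log units; beyond the scatter) in this assay, a loss resting on a 340-fold higher number from compound 2 to compound 1 (2.53 log units; beyond the scatter) but tempered for the change of core. The estimate for compound 4 is 10000 nM, within 2000 nM to 50000 nM.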

Compound 4, half-maximal inhibitory concentration: 290 nM
Compound 4: the middle estimate sits 34-fold (1.54 log units) above what was measured; the whole stated range lies above it.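

In this assay, putting hydrogen in place of trifluoromethyl on the core of compound 3 gave a 4.1-fold higher number from compound 3 to compound 4 (0.62 log units; beyond the scatter), so hydrogen is again the weaker of the two, as it was in the earlier pair, where the same swap gave a 340-fold higher number from compound 2 to compound 1 (2.53 log units; beyond the scatter). The direction of the change carried from one core to the other, but its size did not: the same change on two cores in this assay, a 340-fold higher number (2.53 log units; beyond the scatter) from compound 2 to compound 1 and a 4.1-fold higher number (0.62 log units; beyond the scatter) from compound 3 to compound 4, 81-fold (1.91 log units) apart, beyond the scatter of two such steps These two pairs show that, in this series, a step measured on one core can point the way on another without giving a reliable size, but two pairs make no general rule, and since the pairs differ from each other in more than one place, they cannot say which difference sets the size.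

From the compounds shown here alone, it remains open whether another group in the same place, such as a chlorine atom, a nitrile or a methoxy group, would keep the activity seen with trifluoromethyl. Going by these compounds, it is also open how such a group would behave on each of the two cores.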